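Swapping an Alkyne Arm for a Tellurium-Bearing Aromatic Ring

The source may hold more compounds than are shown below. What is called first, only, known or untested is meant among the compounds shown, and "the series" means these compounds.

Among the measured compounds shown here, in a functional assay on Jurkat cells (Homo sapiens) for cytotoxicity, read by MTT assay, with a stated time of 24 h (a higher number here means that more compound is needed for the effect, a lower number that less compound is needed), compound 1 (`CCCCC#Cc1cc(C(=O)OCC)nc2ccc(OC)cc12`) gives 15900 nM, the lowest of the three numbers measured so far. Compound 2 (`CCOC(=O)c1cc(C#Cc2ccc(N)cc2)c2cc(OC)ccc2n1`) gives 61000 nM, and compound 3 (`CCOC(=O)c1cc(C#Cc2ccccc2[N+](=O)[O-])c2cc(OC)ccc2n1`) gives 54700 nM. Compound 4 (`CCOC(=O)c1cc([Te]c2ccccc2)c2cc(OC)ccc2n1`) has not yet been measured. Its difference from compound 1 is a group of 7 heavy atoms (6 carbon, 1 tellurium; one six-membered aromatic ring of carbon only) in place of a group of 6 heavy atoms (6 carbon; no ring), on an aromatic carbon: hex-1-yn-1-yl leaves an aromatic carbon opposite the ring nitrogen, and a group holding tellurium and a six-membered aromatic ring of carbon only enters there.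

Two measured changes also bring in an aromatic ring in place of butyl, though on a triple-bonded carbon. These are a 3.8-fold higher number from compound 1 to compound 2 (0.58 log units; beyond the scatter) and a 3.4-fold higher number from compound 1 to compound 3 (0.54 log units; beyond the scatter), both modest but beyond the scatter. The comparison a 1.1-fold lower number from compound 2 to compound 3 (0.05 log units; within the scatter) stays within the scatter. None of these steps removes the triple bond or introduces tellurium, so they offer only loose guidance, and the direction they suggest is upward. In this assay the expected change is therefore small, a 1.6-fold higher number from compound 1 to compound 4 (0.20 log units; within the scatter), and may not clear the scatter. For compound 4 the estimated value is 25000 nM, with an expected range from 6000 nM to 80000 nM.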

Compound 4, half-maximal effective concentration: 77400 nM
Compound 4: the middle estimate sits 3.1-fold (0.49 log units) below what was measured; the range from low to high includes it.
By their numbers in this assay, from the lowest: compound 1; then compounds 3, 2 and 4 (each within the scatter of the next).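

Compounds 2 and 3 keep the triple bond and vary only what it carries, whereas compound 4 shows what happens when the whole hex-1-yn-1-yl group on the aromatic carbon opposite the ring nitrogen gives way to a group holding tellurium and a six-membered aromatic ring of carbon only. In this assay this change is a 4.9-fold higher number from compound 1 to compound 4 (0.69 log units; beyond the scatter) and is modest, which places it in the same direction as the two changes that keep the triple bond and bring in an aromatic ring. Among the compounds shown here, compound 1 therefore remains the one needing the least compound among the four, but no measurement at hand bears on why this step occurs.

The change removes the triple bond and brings in both tellurium and an aromatic ring in a single step, so the compounds shown leave the share of each part open. From the compounds shown here alone, a butyl group on tellurium, or sulfur or selenium in place of tellurium, would separate those parts, and whether an amine on the aromatic ring would shift the number at this position also remains open.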